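The compounds below may be only part of what the source reports. "The series", "measured", "known", "first", "only" and "open" are said of these compounds alone.

Three compounds have so far been measured in an ADME assay on Vero cells (Chlorocebus sabaeus) for cytotoxicity, read by MTT assay, with a stated time of 72 h; a higher number here means a weaker inhibitor, a lower number a stronger inhibitor:

Compound 1 `COc1cccc(-c2csc(NC(=O)c3ccc([N+](=O)[O-])cc3)n2)c1` gives > 90000 nM, which is a limit of the assay rather than a number.
Compound 2 `O=C(Nc1nc(-c2cccc(F)c2)cs1)c1ccc([N+](=O)[O-])o1` gives 51600 nM.
Compound 3 `Cc1cc(C)c(-c2csc(NC(=O)c3ccc([N+](=O)[O-])o3)n2)c(C)c1` gives 30400 nM.

Of the two compounds with an actual number, compound 2 has the higher one, but its gap to compound 3 is within the usual scatter of this assay, so the two cannot be told apart on this evidence. All three compounds thus appear as weak inhibitors of the growth of these cells.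

Compound 4 `O=C(Nc1nc(-c2cccc(NC(=O)C3CC3)c2)cs1)c1ccc([N+](=O)[O-])o1` has not yet been measured. Compared with compound 2 it carries one change: (cyclopropylcarbonyl)amino in place of fluoro on an aromatic carbon. Going by the values given here, no pair of already-measured compounds shows a change of this kind, so there is no direct guide to its effect. With so little to go on, compound 4 is expected to land close to compound 2, at an estimated 45000 nM, somewhere between 18000 nM and 90000 nM. The step of a 1.1-fold lower number from compound 2 to compound 4 (0.06 log units; within the scatter) is accordingly expected to stay within the scatter, in no particular direction.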

Compound 4, half-maximal inhibitory concentration in the Vero assay: 35700 nM
The estimate for compound 4 lay 1.3-fold (0.10 log units) above the measured number; low and high end bracket the measured number.
By their numbers in the Vero assay, from the lowest: compounds 3, 4 and 2 (each within the scatter of the next). At a limit, above all of these: compound 1.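

Swapping fluoro for (cyclopropylcarbonyl)amino on this aromatic carbon, meta to a large group, gives in the Vero assay a 1.4-fold lower number from compound 2 to compound 4 (0.16 log units; within the scatter), so compound 2 and compound 4 cannot be told apart there. Going by these compounds alone, this is the first view of this position, and it shows that a much larger group, bringing a ring and a hydrogen-bond donor, can sit here with no readable difference in this cell read-out. The same change does not pass unnoticed in a physicochemical assay for solubility, read by HPLC, with a stated time of 30 min (a higher number here means a more soluble compound, a lower number a less soluble compound), where compound 2 gives 14.8 ug/mL and compound 4 gives 0.47 ug/mL, a large cost in solubility: the measured solubility of compound 2, 14.8 ug/mL, and of compound 4, 0.47 ug/mL, a 31-fold lower number (1.50 log units; beyond the scatter)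

A single pair cannot separate the parts of the (cyclopropylcarbonyl)amino group, such as the three-membered ring and the amide hydrogen. From the compounds shown here alone, how an amine or a carboxylic acid on this carbon would behave in the Vero assay and in the physicochemical assay stays open.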